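A few compounds are considered here, and "the series" means these few. Any claim that something is new, unique, unknown or untested is made for them only; others in the source may bear on it.

Compound 1 `NC(=O)/C=C1\CCc2c1ccc(F)c2F`: 45 mg/kg
Compound 2 `NC(=O)/C=C1/CCc2ccc(F)cc21`: 64 mg/kg
Compound 3 `CCNC(=O)/C=C1\CCc2ccc(F)cc21`: 70 mg/kg

In a functional assay on the whole organism with Mus musculus as the target (a lower number here means that less compound is needed, a higher number that more compound is needed for the effect), the three compounds sit close together. The figure of compound 3 is numerically the highest of the three, yet its distance to compound 2 and its distance to compound 1 both lie within the scatter of this assay, so nothing separates it from either of them.

Compound 4 `O=C(/C=C1\CCc2ccc(F)cc21)NC1CC1` is not yet measured. It differs from compound 3 at one spot: cyclopropyl in place of ethyl on an amide-type nitrogen. For the measured compounds named here, no measured pair in this set shows what this change does, so the step from compound 3 to compound 4 is expected to stay within the scatter, in no particular direction. On that basis compound 4 is estimated at 70 mg/kg, with a range from 35 mg/kg to 140 mg/kg, meaning an expected step of no change at the digits printed from compound 3 to compound 4 (within the scatter).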

Compound 4, dose for half-maximal effect: 66 mg/kg
Beside the measured number, compound 4's estimate is 1.1-fold (0.03 log units) above it; the measured number falls inside the stated range.
By their numbers in this assay, from the lowest: compounds 1, 2, 4 and 3 (each within the scatter of the next).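

In this assay, for the compounds shown here, cyclopropyl in place of ethyl on the amide-type nitrogen gives a 1.1-fold lower number from compound 3 to compound 4 (0.03 log units; within the scatter), the only pair here that reads this position directly. The added three-membered ring of carbon therefore brings no step beyond the scatter at this nitrogen. Nothing at hand bears on why the two groups read alike.

From the compounds shown here alone, whether any group on this nitrogen can move the number beyond the scatter stays open, for example a longer chain, a phenyl ring or a chain carrying an amine or a carboxylic acid. Also open, going by these compounds, is whether the same change reads alike on the core of compound 1.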